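Ring-Nitrogen Methylation on Two Bridged Pyridyl Amines

This account rests on a few compounds, and the source may have more. Where it says the series, first, only, none or still open, it means among the compounds named here.

Compound 1 `Fc1ccc(C2=CC3CNCC(C2)C3)cn1` and compound 2 `C1=C(c2cccnc2)C[C@@H]2CNC[C@H]1C2` are secondary amines on two related bridged cores; the difference between the two cores is not broken down here. In an in vitro functional assay on SH-EP1 cells for agonist activity at Neuronal acetylcholine receptor; alpha4/beta2 (Homo sapiens), read by FLIPR and calcium flux (on this read-out higher numbers stand for an effect only at larger amounts of compound and lower numbers for an effect already at smaller amounts), compound 1 gives 85 nM. In this assay compound 2 gives 35 nM, the lowest of the two numbers, and its gap to compound 1 lies beyond the usual scatter.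

Compound 3 `CN1CC2C=C(c3ccc(F)nc3)CC(C2)C1` differs from compound 1 by methyl in place of hydrogen on an amine nitrogen in a ring. For compound 3 this assay reports only a limit, > 10000 nM. The step is an at least 110-fold higher number from compound 1 to compound 3 (2.07 log units; beyond the scatter); it can be given only as a lower bound because of the limit of > 10000 nM in this assay, at which 1 of the 3 values shown sits.

Compound 4 `CN1C[C@@H]2C=C(c3cccnc3)C[C@@H](C2)C1` carries the same change on compound 2, namely (methyl in place of hydrogen on an amine nitrogen in a ring). Among the compounds with values here, since the only measured example of this change is the large loss from compound 1 to compound 3, compound 4 is expected to lose potency by a comparable amount, a 170-fold higher number from compound 2 to compound 4 (2.23 log units; beyond the scatter). Compound 4 is therefore estimated at 6000 nM in this assay, most plausibly between 1500 nM and 30000 nM, with a real chance that only a limit is reported.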

Compound 4, half-maximal effective concentration: > 10000 nM
Compound 4: a limit, no number; the forecaster's own chance of this, stated with the estimate: 55%; middle value at least 1.6-fold (0.22 log units) away from the limit.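

In this assay compound 4 gives only a limit, > 10000 nM, and not a number. Methyl in place of hydrogen on an amine nitrogen in a ring therefore produces an at least 280-fold higher number from compound 2 to compound 4 (2.45 log units; beyond the scatter), so the large loss seen on the core of compound 1 also appears on the core of compound 2, and in both measured pairs the change carries over in the same direction. This does not show that the loss has the same size on the two cores, nor does it say anything about cores beyond these two: the same change on two cores in this assay, an at least 110-fold higher number (2.07 log units; beyond the scatter) from compound 1 to compound 3 and an at least 280-fold higher number (2.45 log units; beyond the scatter) from compound 2 to compound 4; the limit leaves it open whether they differ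

The compounds shown leave open how far potency falls on each core, since neither methyl compound gives a number: the limit of > 10000 nM in this assay, at which 2 of the 4 values shown sit. They also leave open whether a different group on the same ring nitrogen, such as ethyl, a longer chain or a hydroxyethyl group, would bring the same loss as methyl.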